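Benzyl versus carbamoyl on the ring amine nitrogen

A few compounds are considered here, and "the series" means these few. Any claim that something is new, unique, unknown or untested is made for them only; others in the source may bear on it.

Measured so far in a functional assay on cells (T-cell, Homo sapiens) for inhibition; a higher number here means a weaker inhibitor, a lower number a stronger inhibitor:
compound 1 `COc1ccc(-c2cnc3nc(N)nc(N4CCN(C(=O)NCc5ccc(F)cc5)CC4)c3n2)cc1OC` gives 37 nM
compound 2 `COc1ccc(-c2cnc3nc(N)nc(N4CCN(Cc5ccccc5F)CC4)c3n2)cc1OC` gives 700 nM
compound 3 `COc1ccc(-c2cnc3nc(N)nc(N4CCN(C(=O)Nc5ccccc5)CC4)c3n2)cc1OC` gives 3.4 nM

Compound 3 stands lowest of the three, with both steps to it beyond the scatter, so it is the most potent compound measured here. Compound 4 `COc1ccc(-c2cnc3nc(N)nc(N4CCN(Cc5c(Cl)cccc5Cl)CC4)c3n2)cc1OC` carries the change (2,6-dichlorobenzyl in place of phenylcarbamoyl on an amine nitrogen in a ring). The closest measured steps swap a carbamoyl for a benzyl on the same ring nitrogen: a 210-fold lower number from compound 2 to compound 3 (2.31 log units; beyond the scatter) and a 19-fold higher number from compound 1 to compound 2 (1.28 log units; beyond the scatter). Both point the same way, so compound 4 is expected to lose potency by a large step, a 150-fold higher number from compound 3 to compound 4 (2.17 log units; beyond the scatter), landing near compound 2. Compound 4 is therefore estimated at 500 nM, with a range from 100 nM to 2500 nM.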

Compound 4, half-maximal inhibitory concentration: 7600 nM
Compound 4: the middle estimate sits 15-fold (1.18 log units) below what was measured, outside the stated range (above it).
By their numbers in this assay, from the lowest: compound 3; then compound 1; then compound 2; then compound 4.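

In this assay the cost of a benzyl on this ring nitrogen proves larger than compound 2 alone showed: a 2200-fold higher number from compound 3 to compound 4 (3.35 log units; beyond the scatter) and a 210-fold higher number from compound 1 to compound 4 (2.31 log units; beyond the scatter) are both large steps. The benzyl compounds also do not sit at one level, since 2,6-dichlorophenyl in place of 2-fluorophenyl gives an 11-fold higher number from compound 2 to compound 4 (1.04 log units; beyond the scatter) on the same chain carbon. No measurement at hand accounts for these steps.

Still open, on these data alone, is whether the carbonyl or the amide hydrogen of the carbamoyl carries the difference. An acetyl or a methanesulfonyl on this nitrogen would help separate the two.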